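Nitro for Fluoro on a Fused Sulfonylurea-Receptor Opener Scaffold

The source may hold more compounds than are shown below. What is called first, only, known or untested is meant among the compounds shown, and "the series" means these compounds.

For the measured compounds named here, compound 2 `O=S1(=O)NC(NC2CCC2)=Nc2ccc(F)cc21` holds the higher of the two numbers measured so far in a functional assay for agonist activity at sulfonylurea receptor 1, Kir6.2 (Homo sapiens) (a higher number here means a larger maximal response, a lower number a smaller maximal response), giving 136%. Compound 1 `Nc1ccc2c(c1)S(=O)(=O)NC(NC1CCC1)=N2` carries an amino group where compound 2 carries fluorine; in this assay compound 1 gives 96.9%. Going by the values given here, the one recorded step is a number 39.1 percentage points higher from compound 1 to compound 2 (beyond the scatter). Compound 3 `O=[N+]([O-])c1ccc2c(c1)S(=O)(=O)NC(NC1CCC1)=N2` differs from compound 2 as follows: nitro in place of fluoro on an aromatic carbon. Among the compounds with values here, no measured pair shows a nitro group entering at this position, so the step from compound 1 to compound 2 bears on the site only, not on the change itself. Given that the single known change at this carbon moved the maximal response beyond the scatter, a shift of similar order in either direction cannot be excluded, and the estimate for compound 3 is therefore centred near the known values with a wide range. Compound 3 is expected to give 120%, between 85% and 160%, which corresponds to an expected step of a number 16 percentage points lower from compound 2 to compound 3 (beyond the scatter).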

Compound 3, largest response reached (reported as maximum), in percent of the reference or control that the assay uses: 30.9%
Estimate against measurement, compound 3: 89.1 percentage points above; measured number outside the range, below it.
By their numbers in this assay, from the lowest: compound 3; then compound 1; then compound 2.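

In this assay, nitro in place of fluoro on this aromatic carbon gives a number 105.1 percentage points lower from compound 2 to compound 3 (beyond the scatter), and nitro in place of amino gives a number 66 percentage points lower from compound 1 to compound 3 (beyond the scatter). For the compounds shown here, the earlier pair showed only that the maximal response changes with the group at this carbon; these steps show that it can fall well under the values of both earlier compounds, leaving compound 3 the lowest of the three. No measurement at hand accounts for this drop.

The compounds shown leave open where a methoxy group, a nitrile or a carboxylic acid at this carbon would fall in this wide spread, and where a simple hydrogen would stand against fluoro, amino and nitro. Also open, from the compounds shown here alone, is whether the same order of these three groups would hold with a longer chain on the core's amine nitrogen.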